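The source may report more compounds than this note shows. Statements on the series, on what has been measured and on what is new or still open speak of the compounds shown alone.

Measured compounds in a functional assay on the whole organism for activation, with Mus musculus as the target, with a stated time of 60 min; on this read-out lower numbers stand for an effect already at smaller amounts and higher numbers for an effect only at larger amounts of compound:
Compound 1, `O=C1NC(=O)N(/N=C/c2ccc(-c3ccc(Cl)cc3)o2)C1O`, gives > 1000 mg/kg, a limit of the assay and not a number.
Compound 2, `O=C1NC(=O)N(/N=C/c2ccc(-c3ccc(Cl)c(Cl)c3)o2)C1O`, gives 109 mg/kg.

Compound 1 therefore stands at the upper edge of what this assay reports, (the limit of > 1000 mg/kg in this assay, at which 1 of the 2 values shown sits), with only a limit and no number of its own. Compound 3, `Nc1ccc(-c2ccc(/C=N/N3C(=O)NC(=O)C3O)o2)cc1`, has not yet been measured in this assay. It differs from compound 1 in one place: amino in place of chloro on an aromatic carbon.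

Among the measured compounds shown here, only one measured step exists, an at least 9.1-fold lower number from compound 1 to compound 2 (0.96 log units; beyond the scatter), and it concerns chloro in place of hydrogen on an aromatic carbon, a different change from the one leading to compound 3. It does not speak to what amino in place of chloro does, so no direction can be read from it for the step to compound 3. Because compound 1 sits at a limit, (the limit of > 1000 mg/kg in this assay, at which 1 of the 2 values shown sits), even the size of any step from it cannot be fixed from the numbers at hand.

With nothing pointing the other way, compound 3 is expected to stay close to where compound 1 stands, so the step that the limit leaves unreadable from compound 1 to compound 3 is expected to be small or absent. Compound 3 is estimated at 1500 mg/kg, with a likely range from 300 mg/kg to 6000 mg/kg, and a fair chance that this assay again reports only a limit.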

Compound 3, dose for half-maximal effect: > 1000 mg/kg
Compound 3: a limit, no number (the forecaster's own chance of this, stated with the estimate: 65%); the middle value is on the limit's open side.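

In this assay compound 3 gives > 1000 mg/kg as a limit of the assay and not a number. Compound 1 also stands at a limit, so no step can be read between compound 1 and compound 3: the limit of > 1000 mg/kg in this assay, at which 2 of the 3 values shown sit. The compounds shown leave open what amino in place of chloro does to the dose in this assay when neither compound has a number of its own.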